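The compounds below may be only part of what the source reports. "The series", "measured", "known", "first", "only" and "open" are said of these compounds alone.

In a physicochemical assay for solubility, read by HPLC, in phosphate buffer, measured as kinetic solubility, at pH 7.4 (on this read-out higher numbers stand for higher solubility and lower numbers for lower solubility), compound 1 `CCC(=O)c1cc(-c2ccc(Cl)cc2)n(-c2ccc(S(N)(=O)=O)cc2)c1` gives 19500 nM and sits within the usual scatter of compound 2 `CCOC(=O)c1cc(-c2ccccc2Cl)n(-c2ccc(S(N)(=O)=O)cc2)c1C` at 13700 nM and of compound 3 `CCOC(=O)c1cc(-c2ccc(Cl)cc2)n(-c2ccc(S(N)(=O)=O)cc2)c1` at 10800 nM and no order among the three can be read. Compound 4 `CCC(=O)c1cc(-c2ccc(F)cc2)n(-c2ccc(S(N)(=O)=O)cc2)c1` differs from compound 1 by one change: fluoro in place of chloro on an aromatic carbon with fluoro in place of chloro on an aromatic carbon, so 4-chlorophenyl becomes 4-fluorophenyl. Within the data shown here, the only measured single change is a 1.8-fold lower number from compound 1 to compound 3 (0.26 log units; within the scatter) and it lies within the scatter, but it is ethoxy in place of ethyl on a carbonyl carbon, not a change on an aromatic carbon. Among the measured compounds shown here, with no measured pair for the exchange of chloro for fluoro, the expectation in this assay is no step beyond the scatter. The estimated step is a 1.1-fold higher number from compound 1 to compound 4 (0.05 log units; within the scatter) and remains within the scatter. For compound 4 the estimate is 22000 nM with an expected range from 10000 nM to 48000 nM in this measurement.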

Compound 4, solubility: 63000 nM
The estimate for compound 4 lay 2.9-fold (0.46 log units) below the measured number; measured number above the stated range.
By their numbers in this assay, from the lowest: compounds 3, 2 and 1 (each within the scatter of the next); then compound 4.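

Changing 4-chlorophenyl to 4-fluorophenyl gives a 3.2-fold higher number from compound 1 to compound 4 (0.51 log units; beyond the scatter) in this assay. This is the first step among these compounds to lie beyond the scatter, so the read-out can respond to the exchange of a single atom on this aromatic carbon, whereas the one earlier step, on a carbonyl carbon, stayed within it. Nothing measured here accounts for this step.

Going by these compounds, it remains open whether fluoro for chloro does the same with the ethyl ester of compound 3 in place of the ketone. On these data alone, how an amine or a methoxy group at this position would compare also remains open.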